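The source may report more compounds than this note shows. Statements on the series, on what has been measured and on what is new or still open speak of the compounds shown alone.

Of the compounds shown here, two have been measured in an assay on isolated protein with transient receptor potential cation channel subfamily V member 1 (Homo sapiens) as the target; a higher number here means a larger maximal response, a lower number a smaller maximal response. Compound 1 `O=C(Nc1ccc(Cl)cc1)N1CCN(c2ccncc2)CC1` gives 100%. Compound 2 `O=C(Nc1ccncc1)N1CCN(c2ccccc2C(F)(F)F)CC1` gives 120%, the higher of the two values, and its gap to compound 1 is larger than the usual scatter of this kind of measurement. Compound 3 `O=C(Nc1cccnc1)N1CCN(c2ccccc2C(F)(F)F)CC1` has not yet been measured. It is compound 2 with a single change: pyridin-3-yl in place of pyridin-4-yl on an amide-type nitrogen. The two compounds share every atom and differ only in how those atoms are joined. For the measured compounds named here, no pair of measured compounds shows a change of this kind, so there is no measured guide to how large the step might be. A modest loss in maximal response seems the more likely outcome, though a result within the scatter is also quite possible. For compound 3 in this assay the expected value is 95%, with a range from 60% to 130%. The expected step is a number 25 percentage points lower from compound 2 to compound 3 (beyond the scatter).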

Compound 3, largest response reached (reported as efficacy), in percent of the reference or control that the assay uses: 121%
Beside the measured number, compound 3's estimate is 26 percentage points below it, and the stated range covers the measured number.
By their numbers in this assay, from the lowest: compound 1; then compounds 2 and 3 (each within the scatter of the next).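

Swapping pyridin-4-yl for pyridin-3-yl on an amide-type nitrogen gives a number 1 percentage points higher from compound 2 to compound 3 (within the scatter) in this assay. At this place, then, the maximal response does not separate these two ways of joining the same atoms, something the earlier data could not show, as compound 1 and compound 2 differ in more than one place. Nothing available bears on the reason for this result.

Going by these compounds, this is a single pair, so it remains open whether the same swap would leave the response as undisturbed with a different group on the far side of the shared core. On these data alone, it is also open whether the ring nitrogen matters at all on this amide-type nitrogen, a question that a plain phenyl ring in place of the pyridine would address.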